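Moving the chlorine on a pyridine-linked chlorophenyl ring

The source may hold more compounds than are shown below. What is called first, only, known or untested is meant among the compounds shown, and "the series" means these compounds.

Measured so far:
compound 1, `Oc1cccc(-c2cc(-c3cccnc3)nc(-c3cccc(Cl)c3)c2)c1`, in a functional assay on T47D cells (Homo sapiens) for cytotoxicity, read by CCK-8 assay and cell counting, with a stated time of 2 days; on this read-out lower numbers stand for stronger inhibition and higher numbers for weaker inhibition "not determined" (no result reported);
compound 2, `Oc1cccc(-c2cc(-c3cccc(Cl)c3)nc(-c3ccco3)c2)c1`, this assay 3570 nM;
compound 3, `Oc1cccc(-c2cc(-c3ccccc3)nc(-c3ccc(Cl)cc3)c2)c1`, this assay 11300 nM.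

Compound 3 gives the highest of the two numbers, and the gap to compound 2 lies beyond the scatter. Compound 4, `Oc1cccc(-c2cc(-c3ccccc3)nc(-c3cccc(Cl)c3)c2)c1`, differs from compound 3 only in one place: 3-chlorophenyl in place of 4-chlorophenyl on an aromatic carbon. Going by the values given here, no measured pair shows this exact change on its own, so its size is not known. Compound 2 also carries a 3-chlorophenyl group, but with a different partner ring, so it offers only a loose hint. The step from compound 3 to compound 4 is expected to be small, perhaps toward a lower number, at a 1.7-fold lower number from compound 3 to compound 4 (0.24 log units; within the scatter). Compound 4 is therefore estimated at 6500 nM, within 2500 nM to 16000 nM.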

Compound 4, half-maximal inhibitory concentration: 3700 nM
Estimate against measurement, compound 4: 1.8-fold (0.24 log units) above; low and high end bracket the measured number.
By their numbers in this assay, from the lowest: compounds 2 and 4 (each within the scatter of the next); then compound 3.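

In this assay the move from 4-chlorophenyl to 3-chlorophenyl gives a 3.1-fold lower number from compound 3 to compound 4 (0.48 log units; beyond the scatter) with the same atoms throughout, so where the chlorine sits on this ring matters. Putting phenyl in place of furan-2-yl gives a 1.0-fold higher number from compound 2 to compound 4 (0.02 log units; within the scatter) and so, alongside 3-chlorophenyl, these two partner rings cannot be told apart here. Nothing at hand explains why the chlorine's place counts. Still open, as far as these compounds go, is whether a methoxy group or an amine on this ring would follow the same trend as chlorine.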